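Selenium-bearing quinazoline and pyridopyrimidine analogues against colon cells

The source may hold more compounds than are shown below. What is called first, only, known or untested is meant among the compounds shown, and "the series" means these compounds.

Measured compounds:
compound 1 `CCCCC[Se]c1nc(NCc2ccc(SC)cc2)c2ccccc2n1` — > 100000 nM
compound 2 `CSc1ccc(CNc2nc([SeH])nc3ccccc23)cc1` — > 100000 nM
compound 3 `Nc1nc([SeH])nc2ncccc12` — 89600 nM

In a functional assay on HT-29 cells (Homo sapiens) for cytotoxicity, read by MTT assay, with a stated time of 72 h (on this read-out lower numbers stand for stronger inhibition of growth and higher numbers for weaker inhibition of growth), compound 1 gives only a limit, > 100000 nM. Compound 2 likewise reaches only a limit, > 100000 nM. Within the data shown here, compound 3 gives the only number in this assay, 89600 nM. The change from compound 2 to compound 1 is pentyl in place of hydrogen on a selenium, and its step, a step that the two limits leave unreadable from compound 2 to compound 1, cannot be read because the limit of > 100000 nM in this assay, at which 2 of the 3 values shown sit, covers both ends. The difference between the cores of compound 2 and compound 3 is not broken down here.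

Compound 4 `CCCCC[Se]c1nc(N)c2cccnc2n1` is not yet measured; it arises from compound 3 by the same change, (pentyl in place of hydrogen on a selenium). Since compound 3 stands at 89600 nM, the expected step of a 1.1-fold higher number from compound 3 to compound 4 (0.05 log units; within the scatter) is small and uncertain. Compound 4 is therefore estimated at 100000 nM, between 30000 nM and 300000 nM.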

Compound 4, concentration for total growth inhibition: 20000 nM
Estimate against measurement, compound 4: 5.0-fold (0.70 log units) above; the measured number lies below the stated range.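

In this assay, pentyl in place of hydrogen on a selenium gives a 4.5-fold lower number from compound 3 to compound 4 (0.65 log units; beyond the scatter). Among these compounds, this is the only readable instance of the change, so it shows an effect on the core of compound 3 and nothing yet about any other core. Whether the step carries over to the core of compound 2 stays unknown, because the same change from compound 2 to compound 1 has a limit at both ends and cannot be read: the limit of > 100000 nM in this assay, at which 2 of the 4 values shown sit.

The compounds shown leave open how methyl, a longer chain such as octyl, or benzyl would compare with pentyl on the selenium of compound 4. They also leave open whether any of these groups would bring the core of compound 1 to a readable number.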